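A Cyanophenyl Replaces the Difluorophenyl Arm

This account rests on a few compounds, and the source may have more. Where it says the series, first, only, none or still open, it means among the compounds named here.

Compound 1 `O=C(O)Cc1sc(C(c2ccc(F)cc2)c2ccc(F)cc2)nc1-c1ccc(Cl)cc1`: in an in vitro assay on HEK385-7 cells for displacement of a labelled ligand from prostaglandin D2 receptor 2 (Homo sapiens) (a higher number here means a weaker inhibitor, a lower number a stronger inhibitor), compound 1 gives 9.7 nM
Compound 2 `O=C(O)Cc1sc(C(c2ccc(F)cc2)c2ccc(F)cc2)nc1-c1ccccc1`: in this assay compound 2 gives 16 nM
Compound 3 `O=C(O)Cc1sc(C(c2ccc(F)cc2)c2ccc(F)cc2)nc1-c1cc(F)cc(F)c1`: in this assay compound 3 gives 35 nM

All three share one core; only the aromatic ring on the five-membered aromatic ring with 1 nitrogen and 1 sulfur changes. Compound 3 has the highest number of the three: a 3.6-fold higher number from compound 1 to compound 3 (0.56 log units; beyond the scatter) and a 2.2-fold higher number from compound 2 to compound 3 (0.34 log units; beyond the scatter), both beyond the scatter, while a 1.6-fold higher number from compound 1 to compound 2 (0.22 log units; within the scatter), within it.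

Compound 4 `N#Cc1ccc(-c2nc(C(c3ccc(F)cc3)c3ccc(F)cc3)sc2CC(=O)O)cc1` differs from compound 3 in one place: 4-cyanophenyl in place of 3,5-difluorophenyl on an aromatic carbon. The measured steps show that what sits on this phenyl ring can move the number by a modest amount, and that a plain phenyl and a 4-chlorophenyl both give lower numbers than the 3,5-difluorophenyl. For the measured compounds named here, no compound carries a 4-cyanophenyl here, so its effect is unknown. The expectation is therefore a modest step downward from compound 3 in this assay, of about a 2.3-fold lower number from compound 3 to compound 4 (0.37 log units; beyond the scatter), toward the range of compound 1 and compound 2. Compound 4 is estimated at 15 nM, with a likely range from 5 nM to 50 nM.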

Compound 4, half-maximal inhibitory concentration: 150 nM
For compound 4 the middle estimate is 10-fold (1.00 log units) below the measured one; measured number above the stated range.
By their numbers in this assay, from the lowest: compounds 1 and 2 (each within the scatter of the next); then compound 3; then compound 4.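

In this assay, the 4-cyanophenyl gives a 4.3-fold higher number from compound 3 to compound 4 (0.63 log units; beyond the scatter) and so replaces the 3,5-difluorophenyl as the arm with the highest number in this set. The earlier compounds shown here showed only modest movement at this aromatic carbon of the shared core, and the two direct comparisons on the phenyl ring now widen that picture: cyano in place of hydrogen gives a 9.4-fold higher number from compound 2 to compound 4 (0.97 log units; beyond the scatter) and is also modest, whereas cyano in place of chloro gives a 15-fold higher number from compound 1 to compound 4 (1.19 log units; beyond the scatter) and is large. A single group on this ring can therefore matter much more than the differences among compounds 1, 2 and 3 suggested, although hydrogen and chloro themselves lie within the scatter of each other, and nothing available here explains why cyano stands apart from them.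

Going by these compounds, with so few groups on this ring, it remains open whether the higher number belongs to the nitrile alone or would also appear with a methoxy group, an amine or a carboxylic acid in its place. On these data alone, it also remains open how a trifluoromethyl group or a longer chain would read at this same place on the phenyl ring.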